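The source may report more compounds than this note shows. Statements on the series, on what has been measured and on what is new or still open speak of the compounds shown alone.

Measured compounds in a functional assay on TK-10 cells (Homo sapiens) for inhibition, read by sulforhodamine B assay, with a stated time of 48 h; on this read-out lower numbers stand for stronger inhibition of growth and higher numbers for weaker inhibition of growth:
compound 1 `COc1cc(-c2nn(-c3cccc(NC(=O)Nc4cccc(C(F)(F)F)c4)c3)cc2-c2ccncc2)ccc1Cl` gives 19000 nM
compound 2 `O=C(Nc1cccc(-n2cc(-c3ccncc3)c(-c3ccc(Cl)c(O)c3)n2)c1)Nc1cccc(C(F)(F)F)c1` gives > 32500 nM, which is a limit of the assay and not a number
compound 3 `O=C(Nc1cccc(-n2cc(-c3ccncc3)c(-c3ccc(Cl)c(O)c3)n2)c1)Nc1ccc(Cl)c(C(F)(F)F)c1` gives 11900 nM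

Of the two numbers, compound 1 stands with compound 3 within the usual scatter; the value of compound 2 sits at the limit of > 32500 nM in this assay, at which 1 of the 3 values shown sits.

Compound 4 `COc1cc(-c2nn(-c3cccc(NC(=O)Nc4ccc(Cl)c(Cl)c4)c3)cc2-c2ccncc2)ccc1Cl` is not yet measured in this assay. It differs from compound 1 by 3,4-dichlorophenyl in place of 3-(trifluoromethyl)phenyl on an amide-type nitrogen. Among the measured compounds shown here, no measured step covers this exchange directly. The step of an at least 1.7-fold higher number from compound 1 to compound 2 (0.23 log units; that floor lies within the scatter) concerns the other aryl ring and has no bearing here. For the measured compounds named here, the step of an at least 2.7-fold lower number from compound 2 to compound 3 (0.43 log units; beyond the scatter) adds a chloro on the same ring that is changed here and was at least modest in lowering the number, so a lowering of the number for compound 4 is plausible, though no measured step removes a trifluoromethyl. Compound 4 is therefore expected to give 12000 nM (range 4000 nM to 35000 nM). The expected step is a 1.6-fold lower number from compound 1 to compound 4 (0.20 log units; within the scatter), which may still fall within the scatter.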

Compound 4, concentration for total growth inhibition: 40900 nM
Estimate against measurement, compound 4: 3.4-fold (0.53 log units) below; the measured number lies above the stated range.
By their numbers in this assay, from the lowest: compounds 3 and 1 (each within the scatter of the next); then compound 4.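

In this assay, 3,4-dichlorophenyl in place of 3-(trifluoromethyl)phenyl on the amide-type nitrogen gives a 2.2-fold higher number from compound 1 to compound 4 (0.33 log units; beyond the scatter), so this aryl group cannot be exchanged without a change in the read-out, and the direction here is towards weaker inhibition of growth. The earlier chloro step, an at least 2.7-fold lower number from compound 2 to compound 3 (0.43 log units; beyond the scatter), kept the trifluoromethyl and went the other way, so a gain from chloro on this ring does not carry over to an exchange that also removes the trifluoromethyl. Nothing at hand gives a cause for this step.

Open, going by these compounds, is whether the loss of trifluoromethyl or the chlorines account for the step, which would take chloro and trifluoromethyl together on this ring on the core of compound 1. Also open, on these data alone, is how an amine or a carboxylic acid on this ring would read in this assay.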